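From acetyl to 1,1-dimethylpropyl on a shared core

The compounds below may be only part of what the source reports. "The series", "measured", "known", "first", "only" and "open" are said of these compounds alone.

Measured so far in a functional assay on L5178Y cells (Mus musculus) for antiproliferative activity, read by MTT assay; a lower number here means a stronger inhibitor, a higher number a weaker inhibitor
- compound 1 (`CC(=O)c1ccc(OCCCCN2CCN(c3ncccn3)CC2)cc1`) gives 31.6 nM in this series
- compound 2 (`CC(=O)c1ccc(OCCCCN2CCN(c3ccccn3)CC2)cc1`) gives 24.1 nM in this series

Going by the values given here, compound 1 stands level with compound 2, the only other measured compound, since the one measured step is a 1.3-fold lower number from compound 1 to compound 2 (0.12 log units; within the scatter) and swaps pyridin-2-yl for pyrimidin-2-yl. Compound 3 (`CCC(C)(C)c1ccc(OCCCCN2CCN(c3ncccn3)CC2)cc1`) keeps that pyrimidin-2-yl and the core of compound 1 but carries 1,1-dimethylpropyl in place of acetyl on an aromatic carbon, para to a large group (1,1-dimethylpropyl in place of acetyl on an aromatic carbon). Among the compounds with values here, no measured step touches this group, so the data offer no direct guide to its size or direction. The expectation therefore starts from compound 1 at 31.6 nM and carries no step beyond the scatter in this assay, with wide uncertainty. The expected change is small (a 1.1-fold lower number from compound 1 to compound 3 (0.02 log units; within the scatter)). Compound 3 is estimated at 30 nM (expected range 8 nM to 120 nM).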

Compound 3, half-maximal inhibitory concentration: 17.7 nM
For compound 3 the middle estimate is 1.7-fold (0.23 log units) above the measured one, within the range that was stated.
By their numbers in this assay, from the lowest: compounds 3, 2 and 1 (each within the scatter of the next).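

In this assay the exchange of acetyl for 1,1-dimethylpropyl on the aromatic carbon, para to a large group, stays within the scatter (a 1.8-fold lower number from compound 1 to compound 3 (0.25 log units; within the scatter)). The entering group has no hydrogen-bond acceptor and no double bond outside aromatic rings, so compound 3 shows that a value of this order in the series does not depend on either feature of acetyl. Nothing available bears on why the two groups give values so alike.

As far as these compounds go, whether an amine, a carboxylic acid or a methoxy group on this carbon would also stay within the scatter remains open. So does whether 1,1-dimethylpropyl would behave the same way with pyridin-2-yl in place of pyrimidin-2-yl.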